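The source may hold more compounds than are shown below. What is called first, only, known or untested is meant among the compounds shown, and "the series" means these compounds.

Measured so far:
compound 1 `Cc1ccc(OCC(=O)N(Cc2cccs2)c2ccccn2)cc1` — in an assay on HEK293 cells for agonist activity at transient receptor potential cation channel subfamily M member 8 (Homo sapiens), read by fluorescence and calcium flux, with a stated time of 15 min (on this read-out lower numbers stand for an effect already at smaller amounts and higher numbers for an effect only at larger amounts of compound), compound 1 gives 200 nM
compound 2 `Cc1ccc(OCC(=O)N(Cc2cccs2)c2ccn[nH]2)cc1` — in this assay compound 2 gives 0.2 nM

Compound 2 stands at the lowest of the two numbers; its nearest neighbour is compound 1, and the step of a 1000-fold lower number from compound 1 to compound 2 (3.00 log units; beyond the scatter) separates them, which is far beyond the scatter of this assay. Compound 3 `Cc1ccc(OCC(=O)N(Cc2cccs2)c2cnccn2)cc1` has not been measured. It differs from compound 2 in one place: pyrazin-2-yl in place of 1H-pyrazol-5-yl on an amide-type nitrogen. Within the data shown here, only one measured step bears on this change, the one from compound 1 to compound 2, and it was large. The ring that enters in compound 3 resembles the ring of compound 1 more closely than the ring of compound 2, so the expectation is that most of the gain seen in that step is given back. For compound 3 the estimated step in this assay is therefore a large move to a higher number, a 500-fold higher number from compound 2 to compound 3 (2.70 log units; beyond the scatter). Compound 3 is expected to give about 100 nM, with a range from 10 nM to 1000 nM.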

Compound 3, half-maximal effective concentration: 1240 nM
Compound 3: the middle estimate sits 12-fold (1.09 log units) below what was measured, outside the stated range (above it).
By their numbers in this assay, from the lowest: compound 2; then compound 1; then compound 3.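

In this assay, putting the six-membered pyrazin-2-yl on the amide-type nitrogen in place of the five-membered 1H-pyrazol-5-yl loses the very low number of compound 2 (a 6200-fold higher number from compound 2 to compound 3 (3.79 log units; beyond the scatter)), and pyrazin-2-yl in place of pyridin-2-yl moves in the same direction, though only modestly (a 6.2-fold higher number from compound 1 to compound 3 (0.79 log units; beyond the scatter)). Among these three rings, then, only 1H-pyrazol-5-yl gives a number far below the others, while the two six-membered rings both stay far above it; however, the change from 1H-pyrazol-5-yl to pyrazin-2-yl alters the ring size and removes the hydrogen-bond donor in a single move, so these results cannot separate the two. No measurement offered here explains why these rings differ so sharply.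

From the compounds shown here alone, it remains open whether a five-membered ring is enough or the ring hydrogen is also needed, a question that 1H-imidazol-2-yl or 1-methylpyrazol-5-yl, which has a methyl group on a ring nitrogen, could help to answer. Also open is whether the same ranking of rings would hold if the rest of the shared core were changed, since only this one place varies in the compounds shown.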